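Hydroxy in place of trifluoromethyl on the anilide

The source may hold more compounds than are shown below. What is called first, only, known or untested is meant among the compounds shown, and "the series" means these compounds.

For the measured compounds named here, compound 1 `O=C(Nc1ccc(C(F)(F)F)cc1)C1CCc2ccccc2N1` is the only member of the series with a numerical read-out: in a functional assay on PC-3 cells (Homo sapiens) for cytotoxicity, read by sulforhodamine B assay, with a stated time of 72 h (on this read-out lower numbers stand for stronger inhibition of growth and higher numbers for weaker inhibition of growth), compound 1 gives 20300 nM. Compound 2 `CCCC(=O)N1c2ccccc2CCC1C(=O)Nc1ccccc1C(F)(F)F` reaches only a limit in this assay, > 70000 nM, and that value is a limit rather than a number. The spread of the two values is therefore described by the limit of > 70000 nM in this assay, at which 1 of the 2 values shown sits, which leaves compound 1 as the one fixed point from which a new analogue can be judged.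

Compound 3 `O=C(Nc1ccc(O)cc1)C1CCc2ccccc2N1` is not yet measured in this assay. It differs from compound 1 by hydroxy in place of trifluoromethyl on an aromatic carbon. Going by the values given here, no step between two measured compounds of this kind is available, so the size of the change can only be guessed. The step expected from compound 1 to compound 3 in this assay is a 1.5-fold higher number from compound 1 to compound 3 (0.17 log units; within the scatter), small and, if anything, toward weaker inhibition of growth. Compound 3 is accordingly expected to give about 30000 nM, within a range of 8000 nM to 100000 nM.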

Compound 3, concentration for 50% growth inhibition: > 100000 nM
Compound 3: a limit, no number (the forecaster's own chance of this, stated with the estimate: 35%); middle value at least 3.3-fold (0.52 log units) from the limit.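

At this place on the aromatic ring, para to a large group, the first step read within the series shows that the growth inhibition of compound 1 does not survive hydroxy in place of trifluoromethyl: in this assay the change gives an at least 4.9-fold higher number from compound 1 to compound 3 (0.69 log units; beyond the scatter). Compound 3 stands at > 100000 nM, which is a limit of the assay and not a number. Compound 1 therefore remains the only member of the series with a number, and the step is bounded on one side only: the limit of > 100000 nM in this assay, at which 1 of the 3 values shown sits.

With only trifluoromethyl and hydroxy at this position, the compounds shown cannot separate the effect of losing trifluoromethyl from that of bringing in hydroxy, and they do not tell how a methoxy, a chlorine or a nitrile would read there. On these data alone, compound 2 differs from compound 1 in more than one place and adds nothing to this step, so whether an amine or a carboxylic acid at this position would keep a measurable value in this assay stays open.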